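Compound 3: expected to return from the limit

This account rests on a few compounds, and the source may have more. Where it says the series, first, only, none or still open, it means among the compounds named here.

Compound 1 `COc1ccc(NC(=O)C(=O)c2cn(C(C)C)c3ccccc23)cc1` gives 181 nM
Compound 2 `COc1ccc(NC(=O)C(=O)c2cn(C(C)C)c3ccc(Cl)cc23)cn1` gives > 10000 nM (a limit of the assay)

In a functional assay on FaDu cells (Homo sapiens) for cytotoxicity, read by MTT assay, with a stated time of 72 h (a higher number here means that more compound is tolerated, a lower number that less compound is tolerated), compound 2 gives > 10000 nM, which is a limit and not a number. Compound 3 `COc1ccc(NC(=O)C(=O)c2cn(C(C)C)c3ccc(Cl)cc23)cc1` carries 4-methoxyphenyl in place of 6-methoxypyridin-3-yl on an amide-type nitrogen. Among the measured compounds shown here, no step between measured compounds is available. Compound 1, which also carries 4-methoxyphenyl, gives 181 nM in this assay, and this value supports the expectation. The expected change is an at least 33-fold lower number from compound 2 to compound 3 (1.52 log units; beyond the scatter), a large fall beyond the scatter, towards less compound tolerated. The estimate for compound 3 is 300 nM, with an expected range of 40 nM to 3000 nM.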

Compound 3, concentration lethal to 50% of the cells: > 10000 nM
Compound 3: no number, only a limit (the forecaster's own chance of this, stated with the estimate: 10%); middle value at least 33-fold (1.52 log units) away from the limit.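

In this assay, chloro in place of hydrogen on an aromatic carbon brings an at least 55-fold higher number from compound 1 to compound 3 (1.74 log units; beyond the scatter), so this single change is enough to reach the top of the measurable range while 4-methoxyphenyl stays in place. The value of compound 3, > 10000 nM, is a limit of the assay and not a number. The step from compound 2 to compound 3 cannot be read, because both stand at the same limit: the limit of > 10000 nM in this assay, at which 2 of the 3 values shown sit.

From the compounds shown here alone, what 6-methoxypyridin-3-yl gives with hydrogen in place of chloro stays open. Also open, going by these compounds, is whether fluoro or an amine on that aromatic carbon would bring a readable number.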